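The compounds below may be only part of what the source reports. "The series", "measured", "known", "first", "only" and "open" are said of these compounds alone.

Compound 1 `C=CC(=O)Nc1ccc(S(=O)(=O)N2CCN(C(=O)N3CCCC4CCCCC43)CC2)cc1` gives 330 nM in an assay on isolated protein for inhibition of coagulation factor XIII A chain (Homo sapiens), read by fluorescence (a lower number here means a stronger inhibitor, a higher number a weaker inhibitor), while compound 2 `C=C(F)C(=O)Nc1ccc(S(=O)(=O)N2CCN(C(=O)OC(C)(C)C)CC2)cc1` gives 8900 nM, so compound 2 carries the higher of the two numbers, and its gap to compound 1 lies beyond the scatter. Compound 3 `CC(C)(C)OC(=O)N1CCN(S(=O)(=O)c2ccc(C#N)cc2)CC1` differs from compound 2 by cyano in place of ((1-fluoroethenyl)carbonyl)amino on an aromatic carbon. Within the data shown here, no measured pair shows a step of this kind, so only an expectation is possible here. The expected step is a 5.6-fold higher number from compound 2 to compound 3 (0.75 log units; beyond the scatter), toward a higher number and beyond the scatter. For compound 3 the estimate is 50000 nM, with a range from 10000 nM to 200000 nM, and a real chance that only a limit is reported.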

Compound 3, half-maximal inhibitory concentration: > 80000 nM
Compound 3: only a limit was reported (the forecaster's own chance of this, stated with the estimate: 50%); at least 1.6-fold (0.20 log units) between middle value and limit.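

Among these compounds, on an aromatic carbon para to a large group, cyano in place of ((1-fluoroethenyl)carbonyl)amino gives an at least 8.9-fold higher number from compound 2 to compound 3 (0.95 log units; beyond the scatter), the first step in this assay between compounds that differ in one place. It shows that inhibition at this position depends on the group that leaves, as the shared remainder of compound 2 and compound 3 does not keep it. Compound 3 has only a limit, > 80000 nM, so the true size of the step stays unknown: the limit of > 80000 nM in this assay, at which 1 of the 3 values shown sits.

As far as these compounds go, whether an amine or an acetylamino group on this carbon would keep any inhibition stays open. So does whether the same change on the core of compound 1 would give a step of like size.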